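Adding a Chloro to the Benzyl Arm of Compound 3

A few compounds are considered here, and "the series" means these few. Any claim that something is new, unique, unknown or untested is made for them only; others in the source may bear on it.

Measured so far in a functional assay on the whole organism (artery, strain albino) with Rattus norvegicus as the target, with a stated time of 60 min, at a dose of 10 mg/kg by the oral route; a higher number here means more inhibition at the dose given (going by the name of the read-out), a lower number less inhibition:
compound 1 `COc1ccc(C2N=C(SCc3cccc(Cl)c3)NC(C)=C2C(=O)Nc2ccc(F)cc2)cc1OC` gives 8.2%;
compound 2 `CC1=C(C(=O)Nc2ccc(F)cc2)C(c2ccc([N+](=O)[O-])cc2)N=C(SCc2cccc(Cl)c2)N1` gives 7.2%;
compound 3 `CC1=C(C(=O)Nc2ccc(Br)cc2)C(c2ccc(Cl)cc2Cl)N=C(SCc2ccccc2)N1` gives 6.7%.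

All three share one core and differ only in side groups. Compound 3 holds the lowest of the three numbers shown, but its distance to compound 2 and its distance to compound 1 are both within the scatter, so the three cannot be told apart. Among the measured compounds shown here, the single step between compounds differing in one place, a number 1 percentage points lower from compound 1 to compound 2 (within the scatter), also stays within the scatter.

Compound 4 `CC1=C(C(=O)Nc2ccc(Br)cc2)C(c2ccc(Cl)cc2Cl)N=C(SCc2cccc(Cl)c2)N1` arises from compound 3 by chloro in place of hydrogen on an aromatic carbon. For the measured compounds named here, no measured pair differs in exactly this way, so no step bears directly on it. Compound 1 and compound 2 already carry the 3-chlorobenzyl and sit within the scatter of compound 3. The step expected in this assay is therefore none beyond the scatter, a number 0.8 percentage points higher from compound 3 to compound 4 (within the scatter). Compound 4 is expected to give 7.5%, in the range 0% to 18%.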

Compound 4, a percentage reported as inhibition, in the whole organism at one dose (the size of the read-out at that dose, not a potency): 6.2%
Estimate against measurement, compound 4: 1.3 percentage points above; the range from low to high includes it.
By their numbers in this assay, from the lowest: compounds 4, 3, 2 and 1 (each within the scatter of the next).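

In this assay, among the compounds shown here, going from benzylsulfanyl to (3-chlorobenzyl)sulfanyl gives a number 0.5 percentage points lower from compound 3 to compound 4 (within the scatter), the first reading of this chloro on its own, and at this dose it cannot be told apart from repeat-measurement noise. Compound 1 and compound 2 carry the same 3-chlorobenzyl, but they also differ from compound 3 elsewhere, so they could not isolate this single change. No other measurement is available to explain this result.

Going by these compounds, all four compounds lie within the scatter of one another, so it remains open whether any group on this arm can shift the number at all. A carboxylic acid or an amine on the aromatic ring, or a longer chain in place of the benzyl, would test whether this arm matters in this assay.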